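Substituent on the double-bonded nitrogen: from compound 2 to compound 3

The source may hold more compounds than are shown below. What is called first, only, known or untested is meant among the compounds shown, and "the series" means these compounds.

The series is read in a functional assay on HT-29 cells (Homo sapiens) for cytotoxicity, read by XTT assay, with a stated time of 72 h; on this read-out lower numbers stand for stronger inhibition and higher numbers for weaker inhibition. Compound 1 `COc1ccc(/C(=N\O)c2ccc3c(ccn3C)c2)c(OC)c1OC` carries hydrogen on the oxygen and gives 270 nM. Within the data shown here, compound 2 `COc1ccc(/C(=N\OC(C)=O)c2ccc3c(ccn3C)c2)c(OC)c1OC` carries acetyl on that oxygen and gives 1500 nM; this is the highest of the two numbers so far, and the step of a 5.6-fold higher number from compound 1 to compound 2 (0.74 log units; beyond the scatter) is the only measured step in the set.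

Compound 3 `CN/N=C(/c1ccc2c(ccn2C)c1)c1ccc(OC)c(OC)c1OC` differs from compound 2 by methylamino in place of acetoxy on a double-bonded nitrogen. Among the measured compounds shown here, no measured pair covers this exact exchange. For the measured compounds named here, the one step that bears on it, a 5.6-fold higher number from compound 1 to compound 2 (0.74 log units; beyond the scatter), shows that replacing the hydrogen-bond donor on the double-bonded nitrogen by an acetyl group raised the number modestly. On these data alone, the methylamino group restores a hydrogen-bond donor at that position, so the expectation is that compound 3 moves back toward the number of compound 1 rather than beyond compound 2, but the change of oxygen for nitrogen is untested here, and the uncertainty is wide. Compound 3 is therefore expected to give 600 nM, within 150 nM to 2500 nM, a step of a 2.5-fold lower number from compound 2 to compound 3 (0.40 log units; beyond the scatter).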

Compound 3, half-maximal inhibitory concentration: 2000 nM
For compound 3 the middle estimate is 3.3-fold (0.52 log units) below the measured one, within the range that was stated.
By their numbers in this assay, from the lowest: compound 1; then compounds 2 and 3 (each within the scatter of the next).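

In this assay the exchange of acetoxy for methylamino on a double-bonded nitrogen gives a 1.3-fold higher number from compound 2 to compound 3 (0.12 log units; within the scatter) and so does not separate these two groups. Methylamino does stand apart from hydroxy, with a 7.4-fold higher number from compound 1 to compound 3 (0.87 log units; beyond the scatter) at the same place, so among the three groups shown only hydroxy separates from the others. A hydrogen-bond donor on the group is not enough to hold the lower number, as compound 3 carries one just as compound 1 does, and nothing measured here accounts for the difference.

The set leaves open whether hydroxy is singular at this place or whether other small groups share its number, and methoxy, a plain amino group or dimethylamino on the double-bonded nitrogen would test that. It also leaves open whether the number depends on the atom bound to that nitrogen or on what that atom carries, which a longer chain on the oxygen or a propanoyl group in place of acetyl could begin to separate.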